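The source may hold more compounds than are shown below. What is called first, only, known or untested is meant among the compounds shown, and "the series" means these compounds.

The measured compounds and their values in a functional assay on A549 cells (Homo sapiens) for antiproliferative activity, read by MTT assay, with a stated time of 72 h; on this read-out higher numbers stand for weaker inhibition and lower numbers for stronger inhibition:
Compound 1, `CN1CCN(Cc2ccc(NC(=O)Nc3ccc4ncnc(Nc5cccc(C(F)(F)F)c5)c4c3)cc2)CC1`, gives 1650 nM.
Compound 2, `COC(=O)c1cccc(Nc2ncnc3ccc(NC(=O)Nc4ccc(CN5CCN(C)CC5)cc4)cc23)c1`, gives only a limit of the assay, > 10000 nM.
Compound 3, `O=C(Nc1ccc(CN2CCCCC2)cc1)Nc1ccc2ncnc(Nc3cccc(C(F)(F)F)c3)c2c1`, gives 1050 nM.

Compound 3 carries the lower of the two numbers shown, but the gap to compound 1, a 1.6-fold lower number from compound 1 to compound 3 (0.20 log units; within the scatter), lies within the usual scatter, so the two count as equal in this assay. Within the data shown here, the one step that stands out, an at least 6.0-fold higher number from compound 1 to compound 2 (0.78 log units; beyond the scatter), replaces a group on an aromatic carbon far from the saturated chain carbon and ends at the limit of > 10000 nM in this assay, at which 1 of the 3 values shown sits, so its direction is clear while its full size is not.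

Compound 4, `O=C(Nc1ccc(CN2CCCC2)cc1)Nc1ccc2ncnc(Nc3cccc(C(F)(F)F)c3)c2c1`, has not yet been measured. It differs from compound 3 in one place: pyrrolidin-1-yl in place of piperidin-1-yl on a saturated chain carbon bound to an aromatic carbon. Among the measured compounds shown here, the only measured step at the same place, a 1.6-fold lower number from compound 1 to compound 3 (0.20 log units; within the scatter), stayed within the scatter, even though it exchanged the whole saturated ring for another. Exchanging a six-membered ring for a five-membered one at that place is therefore expected to give no step beyond the scatter, and the expected step is a 1.0-fold higher number from compound 3 to compound 4 (0.02 log units; within the scatter). Compound 4 is thus estimated at about 1100 nM, with a likely range from 500 nM to 2500 nM.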

Compound 4, half-maximal inhibitory concentration: 830 nM
The estimate for compound 4 lay 1.3-fold (0.12 log units) above the measured number, within the range that was stated.
By their numbers in this assay, from the lowest: compounds 4, 3 and 1 (each within the scatter of the next). At a limit, above all of these: compound 2.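

Until now, a single ring exchange at the saturated chain carbon bound to an aromatic carbon had been seen, and it said nothing about ring size. Moving from the six-membered piperidin-1-yl to the five-membered pyrrolidin-1-yl gives a 1.3-fold lower number from compound 3 to compound 4 (0.10 log units; within the scatter) in this assay and thus shows that ring size, at least across these two rings, does not shift the result beyond the scatter. The exchange of 4-methylpiperazin-1-yl for pyrrolidin-1-yl gives a 2.0-fold lower number from compound 1 to compound 4 (0.30 log units; within the scatter) and also stays within the scatter, so all three saturated rings count as equal at this place, though nothing shown explains why.

The compounds shown leave open whether this place needs a saturated ring at all, as an open-chain dimethylamino group, a morpholin-4-yl ring with its oxygen atom, or a longer chain carrying one of the same rings might give a different result. From the compounds shown here alone, it also stays open whether pyrrolidin-1-yl and piperidin-1-yl would still match 4-methylpiperazin-1-yl with methoxycarbonyl in place of trifluoromethyl on the other side of the molecule.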